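The source may report more compounds than this note shows. Statements on the series, on what has been measured and on what is new or still open speak of the compounds shown alone.

In an in vitro ADME assay on microsomes from liver (Homo sapiens) for metabolic stability, read by LC-MS, tested at 1 uM (a higher number here means faster removal of the compound, a lower number slower removal), compound 2 `Cc1ccc(S(=O)(=O)N(C)C(C)C)cc1C#Cc1cc(Cl)ccc1OCC(=O)O` gives < 10 mL.min-1.g-1, which is a limit of the assay and not a number. Compound 3 `COCCNS(=O)(=O)c1ccc(C)c(C#Cc2cc(Cl)ccc2OCC(=O)O)c1` differs from compound 2 by (2-methoxyethyl)amino in place of isopropyl(methyl)amino on a sulfonyl sulfur, with (2-methoxyethyl)amino in place of isopropyl(methyl)amino on a sulfonyl sulfur. Compound 1 `COCCN(C)S(=O)(=O)c1ccc(C)c(C#Cc2cc(Cl)ccc2OCC(=O)O)c1` gives 32 mL.min-1.g-1. Among the measured compounds shown here, the only measured step that bears on this change is an at least 3.2-fold lower number from compound 1 to compound 2 (0.50 log units; beyond the scatter), and its full size stays open because of the limit of < 10 mL.min-1.g-1 in this assay, at which 1 of the 2 values shown sits. That step replaced 2-methoxyethyl with isopropyl on a sulfonamide nitrogen, and here the 2-methoxyethyl group returns, so a rise of modest size or more is expected in this assay. For the measured compounds named here, no measured step covers the rest of the change, so the expectation stays broad. The estimated change is an at least 2.0-fold higher number from compound 2 to compound 3 (0.30 log units; that floor lies within the scatter). For compound 3 the expected value is 20 mL.min-1.g-1, with an estimated range from 10 mL.min-1.g-1 to 40 mL.min-1.g-1.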

Compound 3, intrinsic clearance in microsomes: < 10 mL.min-1.g-1
Compound 3: a limit, no number; the forecaster's own chance of this, stated with the estimate: 20%; middle value at least 2.0-fold (0.30 log units) from the limit.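

In this assay the 2-methoxyethyl group no longer stands alone as the mark of the higher number: hydrogen in place of methyl on the sulfonamide nitrogen gives an at least 3.2-fold lower number from compound 1 to compound 3 (0.50 log units; beyond the scatter) and leaves that group in place. The higher number of compound 1 therefore does not follow from the 2-methoxyethyl group alone, as compound 3 keeps this chain and loses only the methyl. Compound 2 and compound 3 each stand at a limit of the assay and not at a number, and the step between them cannot be read: the limit of < 10 mL.min-1.g-1 in this assay, at which 2 of the 3 values shown sit.

As far as these compounds go, the full size of the fall from compound 1 stays open. Also open, from the compounds shown here alone, is where a longer chain or an amine on the sulfonamide nitrogen would fall in this assay, and whether either gives a readable number.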